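Nitro for trifluoromethyl on a benzimidazole-type aryl series

The compounds below may be only part of what the source reports. "The series", "measured", "known", "first", "only" and "open" are said of these compounds alone.

Measured compounds:
compound 1 `COc1cc(-c2nc3cc([N+](=O)[O-])ccc3[nH]2)ccc1O` gives 19500 nM
compound 2 `COc1cc(-c2nc3cc(C(F)(F)F)ccc3[nH]2)ccc1O` gives 140000 nM
compound 3 `CCOc1ccccc1-c1nc2cc(C(F)(F)F)ccc2[nH]1` gives 549000 nM

In a functional assay on aorta (Rattus norvegicus, strain Wistar) for inhibition, with a stated time of 60 min (on this read-out lower numbers stand for an effect already at smaller amounts and higher numbers for an effect only at larger amounts of compound), compound 3 gives the highest of the three numbers. How the core of compound 3 differs from that of compound 2 is not broken down here. Compound 4 `CCOc1ccccc1-c1nc2cc([N+](=O)[O-])ccc2[nH]1` is not yet measured; it differs from compound 3 by nitro in place of trifluoromethyl on an aromatic carbon. The same change is seen between the measured pair, where compound 1 differs from compound 2 by nitro in place of trifluoromethyl on an aromatic carbon, and there it gave a 7.2-fold lower number from compound 2 to compound 1 (0.86 log units; beyond the scatter) in this assay. Resting on that single step, the number for compound 4 in this assay is expected to fall by about the same amount, so the estimated step is a 6.9-fold lower number from compound 3 to compound 4 (0.84 log units; beyond the scatter). The value of compound 4 is therefore estimated at 80000 nM, with a range from 25000 nM to 250000 nM.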

Compound 4, half-maximal effective concentration: 15000 nM
For compound 4 the middle estimate is 5.3-fold (0.73 log units) above the measured one; the measured number lies below the stated range.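

On the second core, nitro in place of trifluoromethyl again lowered the number in this assay, giving a 37-fold lower number from compound 3 to compound 4 (1.56 log units; beyond the scatter), so the direction of the step carried over. Its size did not carry over, and the two steps differ: the same change on two cores in this assay, a 7.2-fold lower number (0.86 log units; beyond the scatter) from compound 2 to compound 1 and a 37-fold lower number (1.56 log units; beyond the scatter) from compound 3 to compound 4, 5.1-fold (0.71 log units) apart, beyond the scatter of two such steps These two cores alone do not show which feature of a core sets the size of the step, nor how the change would behave on a third core.

The compounds shown leave open how a nitrile, an amine or a carboxylic acid on the same aromatic carbon would compare with nitro. They also leave open whether a longer chain in place of the ethoxy group of compound 4 would alter the number.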